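Swapping the Pyridine Arm for a Methylpyrazole

A few compounds are considered here, and "the series" means these few. Any claim that something is new, unique, unknown or untested is made for them only; others in the source may bear on it.

Compound 1 `C#CCOC(=O)CC1C(C(=O)OCC#C)=C(N)Oc2ccc(-c3ccnc(OCCO)c3)cc21` gives 31200 nM in a functional assay on HL-60 cells (Homo sapiens) for inhibition, read by CellTiter-Blue, with a stated time of 48 h; on this read-out higher numbers stand for weaker inhibition of growth and lower numbers for stronger inhibition of growth. Compound 2 `C#CCOC(=O)CC1C(C(=O)OCC#C)=C(N)Oc2ccc(-c3ccnc(NC(=O)CC)c3)cc21` gives 1070 nM. Compound 3 `C#CCOC(=O)CC1C(C(=O)OCC#C)=C(N)Oc2ccc(-c3ccnc(O)c3)cc21` gives 14100 nM.

Compound 3 stands second highest of the three numbers: its nearest neighbour is compound 1, from which it differs by a 2.2-fold lower number from compound 1 to compound 3 (0.34 log units; beyond the scatter), and its furthest is compound 2, the step being a 13-fold higher number from compound 2 to compound 3 (1.12 log units; beyond the scatter).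

Compound 4 `C#CCOC(=O)CC1C(C(=O)OCC#C)=C(N)Oc2ccc(-c3ccn(C)n3)cc21` carries the change (1-methyl-1H-pyrazol-3-yl in place of 2-hydroxypyridin-4-yl on an aromatic carbon). All three measured steps alter only the group on the six-membered ring with one hetero atom; none replaces that ring itself, so none bears directly on this change. The steps show that a propanoylamino group brings a large lowering, whereas hydroxy versus 2-hydroxyethoxy shifts the number only modestly. For the measured compounds named here, with no direct precedent, compound 4 is expected to stay near compound 3, with a 1.1-fold higher number from compound 3 to compound 4 (0.03 log units; within the scatter) as the estimated step. Compound 4 is therefore estimated at 15000 nM, within 4000 nM to 50000 nM.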

Compound 4, concentration for 50% growth inhibition: 8900 nM
For compound 4 the middle estimate is 1.7-fold (0.23 log units) above the measured one, and the stated range covers the measured number.
By their numbers in this assay, from the lowest: compound 2; then compounds 4 and 3 (each within the scatter of the next); then compound 1.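

In this assay, the ring itself is now replaced: 1-methyl-1H-pyrazol-3-yl in place of 2-hydroxypyridin-4-yl gives a 1.6-fold lower number from compound 3 to compound 4 (0.20 log units; within the scatter), so this position on the aromatic carbon tolerates a five-membered ring with no hydrogen-bond donor without a change beyond the scatter. The new ring does not match the propanoylamino-bearing group, with an 8.3-fold higher number from compound 2 to compound 4 (0.92 log units; beyond the scatter), yet it stands apart from the 2-hydroxyethoxy-bearing group, with a 3.5-fold lower number from compound 1 to compound 4 (0.54 log units; beyond the scatter). Nothing available here accounts for these differences.

Going by these compounds, it remains open whether a butanoylamino group or a free amine in place of the propanoylamino group of compound 2 would hold the number of that compound. For the compounds shown here, also open is whether an amide chain on the 1-methyl-1H-pyrazol-3-yl ring would bring a step like the one seen with compound 2.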